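Ethyl to methyl on the core nitrogen: compound 3

The source may hold more compounds than are shown below. What is called first, only, known or untested is meant among the compounds shown, and "the series" means these compounds.

Measured so far:
compound 1, `CCCn1c(=O)[nH]c2nc(-c3ccc(S(=O)(=O)N(C)C)cc3)[nH]c2c1=O`: 190 nM
compound 2, `CCCn1c(=O)c2[nH]c(-c3ccc(S(=O)(=O)N4CCN(c5ccc(Cl)cc5)CC4)cc3)nc2n(CC)c1=O`: > 1000 nM

Both numbers come from an assay on CHO cells for displacement of a labelled ligand from adenosine receptor A1 (Homo sapiens), read by scintillation counting, with a stated time of 90 min, in the presence of a further agent that is not named here; on this read-out higher numbers stand for weaker inhibition and lower numbers for stronger inhibition. In this assay compound 1 gives 190 nM. For compound 2 the assay reports only a limit, > 1000 nM, which is not a number. This is the limit of > 1000 nM in this assay, at which 1 of the 2 values shown sits, so compound 2 has no measured position beyond sitting at that limit.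

Compound 3, `CCCn1c(=O)c2[nH]c(-c3ccc(S(=O)(=O)N4CCN(c5ccc(Cl)cc5)CC4)cc3)nc2n(C)c1=O`, differs from compound 2 in one place: hydrogen in place of methyl on a saturated chain carbon bound to an aromatic nitrogen, which read one bond further out is ethyl to methyl. Within the data shown here, no measured pair in this set carries this change, so its size in this assay is not known. Loss of a single carbon from a short chain on the shared core is expected to move the number little, within the usual scatter, with no direction favoured. The expected step is a step that the limit leaves unreadable from compound 2 to compound 3. Compound 3 is estimated at 2000 nM, with a range from 700 nM to 6000 nM. The assay may again return only a limit for compound 3 rather than a number.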

Compound 3, inhibition constant: > 1000 nM
Compound 3 gave a limit, no number; the forecaster's own chance of this, stated with the estimate: 65%; the middle value is on the limit's open side.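

In this assay compound 3 gives > 1000 nM, which is a limit and not a number. Compound 2 likewise gives a limit, > 1000 nM. Among these compounds, no step from compound 2 to compound 3 can be read, as both sit at the same limit: the limit of > 1000 nM in this assay, at which 2 of the 3 values shown sit. The compounds shown leave open what size and direction ethyl to methyl has in this assay.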